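The compounds below may be only part of what the source reports. "The series", "measured", "known", "first", "only" and "open" are said of these compounds alone.

Three compounds built on a shared core were tested in a functional assay on SV5A8 cells (Homo sapiens) for cytotoxicity; a higher number here means a weaker inhibitor, a lower number a stronger inhibitor. Compound 1 `Cc1ccc2c(NCc3ccc(NC(=O)C4CCN(Cc5ccc(Cl)cc5)CC4)cc3)nc(N(C)C)nc2c1` carries a 4-chlorophenyl group on a saturated chain carbon bound to an amine nitrogen in a ring. In this assay compound 1 reached only a limit of the assay, > 3180 nM, not a number. Compound 2 `Cc1ccc2c(NCc3ccc(NC(=O)C4CCN(Cc5cccc(F)c5)CC4)cc3)nc(N(C)C)nc2c1` has a 3-fluorophenyl group at that place, and in this assay compound 2 also stopped at a limit, > 4170 nM. Compound 3 `CCCCN1CCC(C(=O)Nc2ccc(CNc3nc(N(C)C)nc4cc(C)ccc34)cc2)CC1` carries a propyl group there, and in this assay compound 3 likewise gave a limit, > 10500 nM. Compound 3 thus stands at one of three limits and cannot be ranked against the others: the limit of > 10500 nM in this assay, at which 1 of the 3 values shown sits, (the limit of > 3180 nM in this assay, at which 1 of the 3 values shown sits), (the limit of > 4170 nM in this assay, at which 1 of the 3 values shown sits).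

Compound 4 `Cc1ccc2c(NCc3ccc(NC(=O)C4CCN(CC(C)C)CC4)cc3)nc(N(C)C)nc2c1` is not yet measured. It differs from compound 3 by isopropyl in place of propyl on a saturated chain carbon bound to an amine nitrogen in a ring. The steps that come closest are a step that the two limits leave unreadable from compound 1 to compound 3 and a step that the two limits leave unreadable from compound 2 to compound 3, and alongside them a step that the two limits leave unreadable from compound 1 to compound 2; none has a readable size, so none shows how a change at this place moves the read-out. No step beyond the scatter is therefore expected in this assay, in either direction, though the limits make even that uncertain. Compound 4 is estimated to give 15000 nM, between 5000 nM and 50000 nM. The expected step, a step that the limit leaves unreadable from compound 3 to compound 4, would most likely show up again only as a limit.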

Compound 4, half-maximal inhibitory concentration: > 10500 nM
Compound 4 was reported as a limit (the forecaster's own chance of this, stated with the estimate: 80%); the middle value is on the limit's open side.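

In this assay compound 4 gave only a limit, > 10500 nM, not a number. Compound 1, compound 2 and compound 3 also gave limits, so none of the steps to compound 4 can be read. The compounds shown leave open how these four rank and whether any change at this place moves the read-out.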